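The source may hold more compounds than are shown below. What is called first, only, known or untested is meant among the compounds shown, and "the series" means these compounds.

Measured so far:
Compound 1, `Cc1cccc(C(=O)Nc2ccc3c(c2)CC(NS(=O)(=O)c2ccccc2)C3)c1-c1ccc(Cl)cc1`, gives 100 nM in an assay on isolated protein for inhibition of microsomal triglyceride transfer protein large subunit (Homo sapiens); on this read-out lower numbers stand for stronger inhibition and higher numbers for weaker inhibition.
Compound 2, `Cc1cccc(C(=O)Nc2ccc3c(c2)CC(CNS(C)(=O)=O)C3)c1-c1ccc(C(F)(F)F)cc1`, gives 150 nM in this assay.

Compound 2 holds the higher of the two numbers, but its nearest neighbour is compound 1, and that gap lies within the scatter of repeated measurements, so the two results cannot be told apart. Among the compounds with values here, the two compounds also differ in more than one place, so no single step between them can be read off.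

Compound 3, `Cc1cccc(C(=O)Nc2ccc3c(c2)CC(CNS(C)(=O)=O)C3)c1-c1ccc(Cl)cc1`, has not been measured. It differs from compound 2 in one place: chloro in place of trifluoromethyl on an aromatic carbon. Compound 1 carries the same chloro substituent and gives 100 nM, while compound 2 with the trifluoromethyl group gives 150 nM, the two sitting within the scatter of one another. This gives no basis for expecting a step beyond the scatter in either direction. The step from compound 2 to compound 3 is therefore expected to be a 1.4-fold lower number from compound 2 to compound 3 (0.13 log units; within the scatter), a movement that stays inside the usual spread. Compound 3 is expected to give 110 nM, with a range from 40 nM to 300 nM.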

Compound 3, half-maximal inhibitory concentration: 500 nM
Beside the measured number, compound 3's estimate is 4.5-fold (0.66 log units) below it, outside the stated range (above it).
By their numbers in this assay, from the lowest: compounds 1 and 2 (each within the scatter of the next); then compound 3.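

On the aromatic carbon para to a large group, the substituent matters more than the earlier pair could show: in this assay, the change from 4-(trifluoromethyl)phenyl to 4-chlorophenyl gives a 3.3-fold higher number from compound 2 to compound 3 (0.52 log units; beyond the scatter) on an otherwise unchanged structure. With chloro held fixed, (methanesulfonamido)methyl in place of (phenylsulfonyl)amino on a saturated ring carbon gives a 5.0-fold higher number from compound 1 to compound 3 (0.70 log units; beyond the scatter) so the saturated ring carbon also responds to substitution, and the indistinguishable results for compound 1 and compound 2 conceal two single-place steps that run in opposite directions. Nothing available bears on the reason for either step.

Still open is whether the gap between trifluoromethyl and chloro carries over to a core bearing (phenylsulfonyl)amino on the saturated ring carbon, since the series shown offers this comparison only with (methanesulfonamido)methyl. Also open, from the compounds shown here alone, is how a nitrile or methoxy group would read on the aromatic carbon, and how a primary amine or carboxylic acid would read on the saturated ring carbon.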